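The compounds below may be only part of what the source reports. "The series", "measured", "known", "first", "only" and "open" are said of these compounds alone.

Working notes on the series. In a functional assay on MCF7 cells (Homo sapiens) for cytotoxicity (on this read-out higher numbers stand for weaker inhibition and lower numbers for stronger inhibition), compound 1 `C=C/C=C\[C@H](C)[C@H](OC(N)=O)[C@@H](C)[C@H](O)[C@@H](C)C/C(C)=C\[C@H](C)[C@@H](O)[C@@H](C)/C=C\CCc1cccc(F)c1` gives 500 nM and compound 2 `C=C/C=C\[C@H](C)[C@H](OC(N)=O)[C@@H](C)[C@H](O)[C@@H](C)C/C(C)=C\[C@H](C)[C@@H](O)[C@@H](C)/C=C\CCc1sccc1C` gives 620 nM. Among the measured compounds shown here, compound 2 stands level with compound 1 on these numbers, and the only other measured compound offers no gap beyond the scatter.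

For the measured compounds named here, compound 3 `C=C/C=C\[C@H](C)[C@H](OC(N)=O)[C@@H](C)[C@H](O)[C@@H](C)C/C(C)=C\[C@H](C)[C@@H](O)[C@@H](C)/C=C\CCc1cccc(OC)c1` has no measurement yet. The change to it is 3-methoxyphenyl in place of 3-methylthiophen-2-yl on a saturated chain carbon, two bonds along the chain from a double-bonded chain carbon.

Going by the values given here, one measured step bears on this: a 1.2-fold higher number from compound 1 to compound 2 (0.09 log units; within the scatter), an exchange at the same place, 3-methylthiophen-2-yl in place of 3-fluorophenyl. Among the compounds with values here, a single step is thin evidence, and no measured compound yet carries 3-methoxyphenyl. Even so, no change beyond the scatter is expected in this assay, because a 1.2-fold higher number from compound 1 to compound 2 (0.09 log units; within the scatter) is the only exchange seen at this place.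

The expected step is a 1.1-fold lower number from compound 2 to compound 3 (0.05 log units; within the scatter), which would stay within the scatter. For compound 3 the estimated value is 550 nM, with an expected range of 220 nM to 1400 nM.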

Compound 3, half-maximal inhibitory concentration: 500 nM
Compound 3: middle estimate off by 1.1-fold (0.04 log units), on the high side; the range from low to high includes it.
By their numbers in this assay, from the lowest: compounds 1, 3 and 2 (each within the scatter of the next).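

In this assay, the exchange at the saturated chain carbon gives a 1.2-fold lower number from compound 2 to compound 3 (0.09 log units; within the scatter) and so stays level, while methoxy in place of fluoro on an aromatic carbon gives no change at the digits printed from compound 1 to compound 3 (within the scatter) on the same phenyl ring. The position now carries three end groups, and the earlier pair could not show that a second substituent on the six-membered aromatic ring of carbon only would also sit level with the five-membered aromatic ring bearing sulfur; among these compounds, none stands apart from the others, and no compound goes against this level pattern. Nothing measured here accounts for this insensitivity to the end group.

The compounds shown all end in a neutral aromatic ring, so it remains open whether this level pattern would hold for an amine or a carboxylic acid on that ring, for a saturated ring such as cyclohexyl in its place, or for a longer chain leading to it. The same exchanges also leave open whether any group at this position can move the number beyond the scatter in either direction.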